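A benzyl swap at the assay limit

The source may report more compounds than this note shows. Statements on the series, on what has been measured and on what is new or still open speak of the compounds shown alone.

Compound 1 `Cc1cc(N2CC[C@@H](C)[C@@H](N(C)c3ncnc4[nH]ccc34)C2)n2nc(SCc3csc4ccc(Cl)cc34)nc2n1`: > 100000 nM (a limit)
Compound 2 `C=CCSc1nc2nc(C)cc(N3CC[C@@H](C)[C@@H](N(C)c4ncnc5[nH]ccc45)C3)n2n1`: 35200 nM
Compound 3 `Cc1cc(N2CC[C@@H](C)[C@@H](N(C)c3ncnc4[nH]ccc34)C2)n2nc(SCc3ccc(F)c(Cl)c3)nc2n1`: > 100000 nM (a limit)

All three were read in a functional assay on HGC-27 cells (Homo sapiens) for inhibition, read by MTT assay, with a stated time of 72 h; a higher number here means a weaker inhibitor, a lower number a stronger inhibitor. Compound 3 gives > 100000 nM, which is a limit and not a number. It shares (the limit of > 100000 nM in this assay, at which 2 of the 3 values shown sit).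

Compound 4 `COc1ccc(CSc2nc3nc(C)cc(N4CC[C@@H](C)[C@@H](N(C)c5ncnc6[nH]ccc56)C4)n3n2)cc1` carries 4-methoxyphenyl in place of 3-chloro-4-fluorophenyl on a saturated chain carbon bound to a sulfur. The closest evidence is an at least 2.8-fold higher number from compound 2 to compound 3 (0.45 log units; beyond the scatter), alongside an at least 2.8-fold lower number from compound 1 to compound 2 (0.45 log units; beyond the scatter), while a step that the two limits leave unreadable from compound 1 to compound 3. Both measured compounds with an aromatic ring at that place sit at the limit, and compound 4 keeps such a ring. In this assay no step beyond the scatter is therefore expected, and the estimated step is an at least 1.2-fold lower number from compound 3 to compound 4 (0.09 log units; that floor lies within the scatter). Compound 4 is estimated at 80000 nM, with an expected range of 30000 nM to 150000 nM.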

Compound 4, half-maximal inhibitory concentration: 18200 nM
Beside the measured number, compound 4's estimate is 4.4-fold (0.64 log units) above it; measured number outside the range, below it.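

In this assay, going by these compounds alone, an aromatic ring on the saturated chain carbon bound to a sulfur no longer leaves a compound at the limit: 4-methoxyphenyl gives an at least 5.4-fold lower number from compound 3 to compound 4 (0.73 log units; beyond the scatter) and an at least 5.4-fold lower number from compound 1 to compound 4 (0.73 log units; beyond the scatter). Set against the vinyl of compound 2, it gives a 1.9-fold lower number from compound 2 to compound 4 (0.29 log units; within the scatter), so the ring alone does not decide the outcome at this place. The values of compound 1 and compound 3 remain limits, not numbers: the limit of > 100000 nM in this assay, at which 2 of the 4 values shown sit.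

The change removes chlorine and fluorine and adds methoxy at once, and the compounds shown do not separate these parts. Going by these compounds, how a plain benzyl, or a benzyl carrying an amine or a carboxylic acid, would read also stays open.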